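Ethylphenyl in Place of Dimethylphenyl on the Sulfur

A few compounds are considered here, and "the series" means these few. Any claim that something is new, unique, unknown or untested is made for them only; others in the source may bear on it.

Of the compounds shown here, three have been measured in a functional assay on A549 cells (Homo sapiens) for inhibition, read by CCK-8 assay, with a stated time of 72 h, tested at 8 uM; on this read-out lower numbers stand for less inhibition of growth and higher numbers for more inhibition of growth at the one concentration tested. Compound 1 `Nc1ccccc1NC(=O)c1ccc(CSc2ccc(Br)cc2)cc1` gives 45.7%, compound 3 `COc1ccc(SCc2ccc(C(=O)Nc3ccccc3N)cc2)cc1` gives 70.7%, and compound 2 `Cc1cc(C)cc(SCc2ccc(/C=C/C(=O)Nc3ccccc3N)cc2)c1` gives 47.3%. Compound 2 stands second highest of the three: its number lies within the scatter of compound 1, while compound 3 sits higher by a gap beyond the scatter. Within the data shown here, the only step between measured compounds that differ in one place is a number 25 percentage points higher from compound 1 to compound 3 (beyond the scatter); that step puts methoxy in place of bromo on an aromatic carbon, a change of a different kind from the one considered here.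

Compound 4 `CCc1ccc(SCc2ccc(/C=C/C(=O)Nc3ccccc3N)cc2)cc1` differs from compound 2 in one place: 4-ethylphenyl in place of 3,5-dimethylphenyl on a sulfur. The two have the same atoms, joined differently. Among the measured compounds shown here, no measured step shows what such a change does in this assay, and the bromo-to-methoxy step gives no guide to it. Compound 4 is therefore expected to come in near compound 2, with no step beyond the scatter. The estimate for compound 4 is 47%, with a range from 35% to 60%, which means an expected step of a number 0.3 percentage points lower from compound 2 to compound 4 (within the scatter).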

Compound 4, percent growth inhibition at one concentration: 68.6%
For compound 4 the middle estimate is 21.6 percentage points below the measured one, and the stated range ends below it.
By their numbers in this assay, from the lowest: compounds 1 and 2 (each within the scatter of the next); then compounds 4 and 3 (each within the scatter of the next).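

In this assay, putting 4-ethylphenyl in place of 3,5-dimethylphenyl on a sulfur gives a number 21.3 percentage points higher from compound 2 to compound 4 (beyond the scatter). The group that leaves and the group that enters have the same count of heavy atoms, the same kind of aromatic ring and no hydrogen-bond donors or acceptors, so the way the same carbons are joined is enough on its own to move the number beyond the scatter, something the bromo-to-methoxy step could not show, as that step exchanged different atoms. Nothing at hand accounts for why this rearrangement has such an effect.

Going by these compounds, it remains open whether the ethyl group, its place on the ring or the loss of the two methyl groups decides the outcome, a question that 4-methylphenyl, 3-ethylphenyl or 4-propylphenyl on the sulfur could address. Also open, on these data alone, is whether the same change would have a similar effect on the core of compound 3.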